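The compounds below may be only part of what the source reports. "The series", "measured", "known", "first", "only" and "open" are said of these compounds alone.

Of the compounds shown here, three built on one shared core have been measured in an assay on THP-1 cells for antagonist activity at P2X purinoceptor 7 (Homo sapiens), read by ELISA, with a stated time of 30 min; on this read-out lower numbers stand for stronger inhibition and higher numbers for weaker inhibition. Compound 1, `CNC(=O)c1cccc(S(=O)(=O)Oc2ccc(-c3cncn3C3CCN(C(=O)c4ccc(Cl)c(C(F)(F)F)c4)CC3)cc2)c1`, gives 1.76 nM. Compound 2, `O=C(NC1CC1)c1cccc(S(=O)(=O)Oc2ccc(-c3cncn3C3CCN(C(=O)c4ccc(Cl)c(C(F)(F)F)c4)CC3)cc2)c1`, carries a cyclopropyl in place of methyl on an amide-type nitrogen and gives 58 nM. That single change brought a 33-fold higher number from compound 1 to compound 2 (1.52 log units; beyond the scatter). Compound 3, `CNC(=O)c1cccc(S(=O)(=O)Oc2ccc(-c3cncn3C3CCN(C(=O)c4ccc(N(C)C)cc4)CC3)cc2)c1`, instead carries a (4-(dimethylamino)phenyl in place of 4-chloro-3-(trifluoromethyl)phenyl on a carbonyl carbon), and in this assay compound 3 gives 22 nM, which is a 13-fold higher number from compound 1 to compound 3 (1.10 log units; beyond the scatter).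

Compound 4, `CN(C)c1ccc(C(=O)N2CCC(n3cncc3-c3ccc(OS(=O)(=O)c4cccc(C(=O)NC5CC5)c4)cc3)CC2)cc1`, is not yet measured. It differs from compound 3 by a (cyclopropyl in place of methyl on an amide-type nitrogen); this is the same change that turns compound 1 into compound 2, made on a core that differs from the core of compound 1 by the 4-(dimethylamino)phenyl in place of 4-chloro-3-(trifluoromethyl)phenyl on a carbonyl carbon just described. Both times the change sits on an amide-type nitrogen whose other neighbour is a carbonyl carbon, so the surroundings of the change are the same in words.

Within the data shown here, for compound 4 the step from compound 3 is expected to be a 27-fold higher number from compound 3 to compound 4 (1.44 log units; beyond the scatter), close in size to the step seen once before, because a 33-fold higher number from compound 1 to compound 2 (1.52 log units; beyond the scatter) is the only measured example of this change and it was large. With the change seen only once, how far the size carries over to a second core is uncertain, and the range is set wide. The estimate for compound 4 in this assay is 600 nM, expected between 150 nM and 2500 nM.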

Compound 4, half-maximal inhibitory concentration: 1.03 nM
The estimate for compound 4 lay 580-fold (2.77 log units) above the measured number; the whole stated range lies above it.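

In this assay, putting cyclopropyl in place of methyl on the amide-type nitrogen did not carry over from one core to the other, since on the core of compound 3 it gave a 21-fold lower number from compound 3 to compound 4 (1.33 log units; beyond the scatter), the opposite direction to the earlier step: the same change on two cores in this assay, a 33-fold higher number (1.52 log units; beyond the scatter) from compound 1 to compound 2 and a 21-fold lower number (1.33 log units; beyond the scatter) from compound 3 to compound 4, 700-fold (2.85 log units) apart, beyond the scatter of two such steps

The other change behaves the same way, as 4-(dimethylamino)phenyl in place of 4-chloro-3-(trifluoromethyl)phenyl on the carbonyl carbon gave a 56-fold lower number from compound 2 to compound 4 (1.75 log units; beyond the scatter), again opposite to the step seen earlier: the same change on two cores in this assay, a 13-fold higher number (1.10 log units; beyond the scatter) from compound 1 to compound 3 and a 56-fold lower number (1.75 log units; beyond the scatter) from compound 2 to compound 4, 700-fold (2.85 log units) apart, beyond the scatter of two such steps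

Across these four compounds, then, the effect of each change, in both size and direction, depends on which group sits at the other site, so neither change can be read as a fixed increment; what the numbers do not show is why this happens, or which of the two directions would hold on a further core.

From the compounds shown here alone, it remains open how a third group on the amide-type nitrogen, such as ethyl, would behave with each of the two groups on the carbonyl carbon. Going by these compounds, it is equally open whether a plain phenyl on the carbonyl carbon would follow the pattern of compound 1 and compound 2 or that of compound 3 and compound 4.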